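Bromo for iodo: a halogen swap in two cytotoxic compounds

The compounds below may be only part of what the source reports. "The series", "measured", "known", "first", "only" and "open" are said of these compounds alone.

Compound 1 `CCCCC1=C(Br)/C(=C/Br)OC1=O`: 10.2 ug/mL
Compound 2 `CCC[C@@H](O)C1=C(Br)/C(=C/I)OC1=O`: 0.3 ug/mL

In a functional assay on ZR-75-1 cells (Homo sapiens) for cytotoxicity (a lower number here means that less compound is needed, a higher number that more compound is needed for the effect), compound 2 gives 0.3 ug/mL, the lower of the two numbers, while compound 1 gives 10.2 ug/mL, a gap well beyond the scatter. Compound 3 `CCC[C@@H](O)C1=C(Br)/C(=C/Br)OC1=O` differs from compound 2 in one place: bromo in place of iodo on a double-bonded chain carbon bound to a double-bonded ring carbon. Among the compounds with values here, no measured pair shows this single swap on its own, so the expectation rests on a small change. The step from compound 2 to compound 3 is expected to be modest, a 2.0-fold higher number from compound 2 to compound 3 (0.30 log units; within the scatter), toward a slightly higher number. Compound 3 is therefore estimated at 0.6 ug/mL, within 0.2 ug/mL to 2.5 ug/mL.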

Compound 3, concentration for half-maximal effect: < 0.1 ug/mL
Compound 3 was reported as a limit; the forecaster's own chance of this, stated with the estimate: 2%; middle value at least 6.0-fold (0.77 log units) from the limit.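

Compound 1 and compound 2 differ in two places, so their gap could not be assigned to either change, and compound 3 now separates the two. At the halogen position, bromo in place of iodo gives an at least 3.0-fold lower number from compound 2 to compound 3 (0.47 log units; beyond the scatter), so this swap alone moves the number beyond the scatter, and in the opposite direction to the small rise expected. On the chain, hydroxy in place of hydrogen gives an at least 100-fold lower number from compound 1 to compound 3 (2.00 log units; beyond the scatter).

From the compounds shown here alone, compound 3 is reported only as a limit, so the true size of both steps stays open: the limit of < 0.1 ug/mL in this assay, at which 1 of the 3 values shown sits. Also open is whether chloro at the halogen position, or an amine in place of the hydroxy, would keep this effect.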